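Swapping the oxadiazole of compound 2 for pyridazine

The source may report more compounds than this note shows. Statements on the series, on what has been measured and on what is new or still open speak of the compounds shown alone.

Measured so far in an ADME assay on cells (Hepatocyte, Rattus norvegicus) for metabolic stability; a lower number here means that the compound disappears faster, a higher number that the compound lasts longer:
Compound 1 `O=C(C1CCN(c2ncccn2)CC1)N1N=CC[C@H]1c1ccccc1`: 0.137 h
Compound 2 `Cc1nnc(N2CCC(C(=O)N3N=CC[C@H]3c3ccccc3)CC2)o1`: 2.88 h
Compound 3 `Cc1nnc(N2CCC(C(=O)N3N=CC[C@H]3c3cc(F)cc(F)c3)CC2)o1`: 3.3 h

In this assay, compound 2 and compound 3 lie within the usual scatter of each other, and both lie far above compound 1. The next molecule, compound 4 `O=C(C1CCN(c2cccnn2)CC1)N1N=CC[C@H]1c1ccccc1`, alters compound 2 in one place: pyridazin-3-yl in place of 5-methyl-1,3,4-oxadiazol-2-yl on an amine nitrogen in a ring.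

The closest evidence comes from that same place: a 21-fold higher number from compound 1 to compound 2 (1.32 log units; beyond the scatter), when 5-methyl-1,3,4-oxadiazol-2-yl replaced pyrimidin-2-yl. Compound 4 also gives up the 5-methyl-1,3,4-oxadiazol-2-yl group, so part of that large step may be undone. Yet pyridazin-3-yl is not pyrimidin-2-yl, and no measurement of it exists here, so a full reversal would be too bold a guess. The other measured change, a 1.1-fold higher number from compound 2 to compound 3 (0.06 log units; within the scatter), concerns the phenyl group and says little about this place.

A clear fall is therefore expected, with the estimated step being a 4.8-fold lower number from compound 2 to compound 4 (0.68 log units; beyond the scatter). Compound 4 is expected to show about 0.6 h, with an estimated range of 0.17 h to 2 h.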

Compound 4, half-life: < 0.517 h
Compound 4: a limit, no number; the forecaster's own chance of this, stated with the estimate: 3%; middle value at least 1.1-fold (0.06 log units) away from the limit.
By their numbers in this assay, from the lowest: compound 1; then compounds 2 and 3 (each within the scatter of the next).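

The large step of a 21-fold higher number from compound 1 to compound 2 (1.32 log units; beyond the scatter) could have been peculiar to leaving pyrimidin-2-yl, but the step of an at least 5.5-fold lower number from compound 2 to compound 4 (0.74 log units; beyond the scatter) shows that a second six-membered aromatic ring on the same amine nitrogen also stands far from 5-methyl-1,3,4-oxadiazol-2-yl. Among the three groups shown at this place, the high half-life therefore goes with the oxadiazole, and no exception appears, although three groups are too few for a general rule. Compound 4 gives < 0.517 h in this assay, which is a limit of the assay and not a number, so its step from compound 1 cannot be read.

From the compounds shown here alone, it remains open whether the ring itself or its methyl group carries the effect. A 1,3,4-oxadiazol-2-yl without the methyl, or a 5-methyl-1,3,4-thiadiazol-2-yl, would separate these two parts.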